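Trifluoromethyl for fluoro on two aniline cores

This account rests on a few compounds, and the source may have more. Where it says the series, first, only, none or still open, it means among the compounds named here.

The series rests on a shared core carrying a substituted anilino group, read in an assay on mitochondria from L6 cells (Rattus norvegicus) for activation, with a stated time of 90 min; on this read-out higher numbers stand for an effect only at larger amounts of compound and lower numbers for an effect already at smaller amounts. Compound 1 `Oc1nc2nonc2nc1Nc1ccc(OCCCC(F)(F)F)c(F)c1` gives 4200 nM in this assay. Compound 2 `Oc1nc2nonc2nc1Nc1ccc(OCCCC(F)(F)F)c(C(F)(F)F)c1`, in which the change is trifluoromethyl in place of fluoro on an aromatic carbon, gives 2100 nM in this assay, so that a 2.0-fold lower number from compound 1 to compound 2 (0.30 log units; within the scatter). Compound 3 `Oc1nc2nonc2nc1Nc1cccc(F)c1F` gives 9700 nM in this assay, the highest of the three numbers, and its gaps to compound 1 and compound 2 are beyond the scatter. The difference between the core of compound 3 and the core of compound 1 is not broken down here.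

Compound 4 `Oc1nc2nonc2nc1Nc1cccc(C(F)(F)F)c1F` has not yet been measured in this assay. It differs from compound 3 by trifluoromethyl in place of fluoro on an aromatic carbon. Going by the values given here, this is the same kind of change as the one from compound 1 to compound 2, not the same: in compound 2 the entering group sits ortho to a 4,4,4-trifluorobutoxy group, whereas in compound 4 it sits ortho to a fluoro group, meta to a large group in both cases. Taking the earlier step as a guide, a step of a 1.8-fold lower number from compound 3 to compound 4 (0.25 log units; within the scatter) is expected, since compound 1 to compound 2 gave a 2.0-fold lower number from compound 1 to compound 2 (0.30 log units; within the scatter). On that basis compound 4 is estimated at 5500 nM in this assay, expected to lie between 2500 nM and 12000 nM.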

Compound 4, half-maximal effective concentration: 4900 nM
Beside the measured number, compound 4's estimate is 1.1-fold (0.05 log units) above it, within the range that was stated.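

In this assay, trifluoromethyl in place of fluoro on an aromatic carbon gives a 2.0-fold lower number from compound 3 to compound 4 (0.30 log units; within the scatter). Set beside the earlier step, the change reads the same on both cores: the same change on two cores in this assay, a 2.0-fold lower number (0.30 log units; within the scatter) from compound 1 to compound 2 and a 2.0-fold lower number (0.30 log units; within the scatter) from compound 3 to compound 4, 1.0-fold (0.00 log units) apart, within the scatter of two such steps. This agreement shows that, across these two pairs, the step does not depend on the core to any extent these numbers can detect, but each step lies within the scatter on its own, so the two together do not establish that the change moves the number at all, and they say nothing about any further core.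

The compounds shown leave open whether another group on the same aromatic carbon, such as a nitrile, a methoxy group, an amine or a carboxylic acid, would read differently from fluoro or trifluoromethyl. They also leave open how much of the gap between the two cores belongs to the 4,4,4-trifluorobutoxy chain, and whether a shorter or longer chain in its place would alter the picture, since no pair shown isolates that part of the structure.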